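Expected step from compound 3 to compound 4

The source may report more compounds than this note shows. Statements on the series, on what has been measured and on what is new or still open speak of the compounds shown alone.

In a functional assay on HT-29 cells (Homo sapiens) for antiproliferative activity, read by sulforhodamine B assay, with a stated time of 48 h (on this read-out higher numbers stand for weaker inhibition and lower numbers for stronger inhibition), compound 3 (`CCCN1CCN(c2ccc(S(=O)(=O)Oc3ccccc3CC)cc2)C1=O`) reads > 100000 nM and that reading is a limit of the assay and not a number. Compound 1 (`CCc1ccccc1OS(=O)(=O)c1ccc(N2CCN(C)C2=O)cc1`) gives 4600 nM in this assay and compound 2 (`CN1CCN(c2ccc(S(=O)(=O)Oc3cccc(Cl)c3)cc2)C1=O`) gives 2100 nM there.

Compound 4 (`CCCN1CCN(c2ccc(S(=O)(=O)Oc3cccc(OC)c3)cc2)C1=O`) has 3-methoxyphenyl in place of 2-ethylphenyl on the oxygen bound to the sulfonyl sulfur (3-methoxyphenyl in place of 2-ethylphenyl on an oxygen) and keeps the propyl group of compound 3.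

Among the compounds with values here, two measured steps bear on this change. The closer one shows a 2.2-fold lower number from compound 1 to compound 2 (0.34 log units; beyond the scatter) as a modest change, with 3-chlorophenyl in place of 2-ethylphenyl on the same oxygen. It concerns a different entering group, so it serves only as a guide to direction. The other is large and shows an at least 21-fold higher number from compound 1 to compound 3 (1.33 log units; beyond the scatter) for the change that compound 3 and compound 4 share.

On the strength of compound 2 and a 2.2-fold lower number from compound 1 to compound 2 (0.34 log units; beyond the scatter) a lower number is expected in this assay for the new compound. With an at least 21-fold higher number from compound 1 to compound 3 (1.33 log units; beyond the scatter) still in force, that number is expected to stay well short of the values of compound 1 and compound 2.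

The expected change is an at least 2.0-fold lower number from compound 3 to compound 4 (0.30 log units; that floor lies within the scatter) and the reading may again end at the limit of the assay.

For compound 4 the estimated value is 50000 nM with an expected range from 12000 nM to 100000 nM as a working figure.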

Compound 4, half-maximal inhibitory concentration: 25000 nM
The estimate for compound 4 lay 2.0-fold (0.30 log units) above the measured number, and the stated range covers the measured number.
By their numbers in this assay, from the lowest: compound 2; then compound 1; then compound 4. At a limit, above all of these: compound 3.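

In this assay the exchange of 2-ethylphenyl for 3-methoxyphenyl on the oxygen bound to the sulfonyl sulfur gives an at least 4.0-fold lower number from compound 3 to compound 4 (0.60 log units; beyond the scatter) and so shows that a compound carrying the propyl group can return a measurable reading. Compound 3 reads > 100000 nM, which is a limit of the assay and not a number, so this step has only a floor and its full size stays unread: the limit of > 100000 nM in this assay, at which 1 of the 4 values shown sits. A lower number on leaving 2-ethylphenyl had been seen only with the methyl group of compound 1 in place, as a 2.2-fold lower number from compound 1 to compound 2 (0.34 log units; beyond the scatter) with 3-chlorophenyl entering, and it now holds with the propyl group as well, with no compound shown going against it.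

The compounds shown leave open how 3-methoxyphenyl reads with the methyl group in place of propyl, so the cost of the propyl group cannot be read for this entering group. They also leave open whether a hydroxyl, an amine or a carboxylic acid on the phenyl ring at this oxygen would keep the lower number seen with 3-methoxyphenyl.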